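Aryl amide swap on a tetrazole sterol O-acyltransferase inhibitor

The source may hold more compounds than are shown below. What is called first, only, known or untested is meant among the compounds shown, and "the series" means these compounds.

Measured so far:
compound 1 `CCCCCCCCCCCCn1nnc(C(NC(=O)c2ccc(F)cc2F)c2ccccc2)n1`: 490 nM
compound 2 `CCCCCCCCCCCCn1nnc(C(NC(=O)c2ccc(OC)cc2)c2ccccc2)n1`: 600 nM

Of the compounds shown here, two sharing the same core have been measured in an assay on microsomes from liver for inhibition of sterol O-acyltransferase 1 (Rattus norvegicus); on this read-out lower numbers stand for stronger inhibition and higher numbers for weaker inhibition. Compound 1 gives 490 nM, the lowest of the two numbers, and compound 2 gives 600 nM; the step of a 1.2-fold higher number from compound 1 to compound 2 (0.09 log units; within the scatter) lies within the scatter, so neither can be ranked ahead of the other.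

Compound 3 `CCCCCCCCCCCCn1nnc(C(NC(=O)c2ccccc2C(F)(F)F)c2ccccc2)n1` is not yet measured. It differs from compound 1 by 2-(trifluoromethyl)phenyl in place of 2,4-difluorophenyl on a carbonyl carbon. For the measured compounds named here, the only measured step that bears on it is the aryl exchange on the carbonyl carbon, a 1.2-fold higher number from compound 1 to compound 2 (0.09 log units; within the scatter), which produced no change beyond the scatter. On that basis, no step beyond the scatter is expected for compound 3 in this assay either, though with a single precedent the range is kept wide. Compound 3 is therefore estimated at 600 nM, within 200 nM to 1800 nM, corresponding to an expected step of a 1.2-fold higher number from compound 1 to compound 3 (0.09 log units; within the scatter).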

Compound 3, half-maximal inhibitory concentration: 120 nM
Estimate against measurement, compound 3: 5.0-fold (0.70 log units) above; the measured number lies below the stated range.
By their numbers in this assay, from the lowest: compound 3; then compounds 1 and 2 (each within the scatter of the next).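

In this assay, the aryl group on the carbonyl carbon proves able to move the number beyond the scatter: 2-(trifluoromethyl)phenyl in place of 2,4-difluorophenyl gives a 4.1-fold lower number from compound 1 to compound 3 (0.61 log units; beyond the scatter), and in place of 4-methoxyphenyl it gives a 5.0-fold lower number from compound 2 to compound 3 (0.70 log units; beyond the scatter). The earlier exchange at this place showed no step beyond the scatter, so the exchange of one aryl group for another is not neutral in every case, and compound 3 now stands apart from compounds 1 and 2, which still cannot be ranked against each other. Nothing available here explains why this exchange registers when the earlier one did not.

The compounds shown leave open whether a chlorine atom or a nitrile on the same ring would give a similar number to the trifluoromethyl group. They also leave open whether the lower number of compound 3 would persist with a shorter chain on the shared core.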